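The compounds below may be only part of what the source reports. "The series", "measured", "known", "first", "only" and "open" are said of these compounds alone.

Compound 1 `Cc1nc2c([nH]1)C(=O)/C(=N/c1ccc(Cl)cc1)C(Cl)=C2O`: 2800 nM; 2820 nM (2 entries) in an ADME assay (Rattus norvegicus) for inhibition; on this read-out lower numbers stand for stronger inhibition and higher numbers for weaker inhibition
Compound 2 `O=C1C=C(Nc2ccc(Cl)cc2)C(=O)c2[nH]c(-c3ccccn3)nc21`: 13000 nM

In this assay, within the data shown here, compound 2 gives the only number on record for it, 13000 nM; one further entry for it gives no single number. Compound 3 `O=C1C=C(Nc2ccc(OC(F)(F)F)cc2)C(=O)c2[nH]c(-c3ccccn3)nc21` carries trifluoromethoxy in place of chloro on an aromatic carbon, trifluoromethoxy in place of chloro on an aromatic carbon. Among the measured compounds shown here, no step between two measured compounds speaks to this change. The step of a 1.3-fold lower number from compound 2 to compound 3 (0.11 log units; within the scatter) is therefore expected to be modest, open in direction, and not necessarily beyond the usual scatter. In this assay compound 3 is estimated at 10000 nM, with a range from 3000 nM to 40000 nM.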

Compound 3, half-maximal inhibitory concentration: 20000 nM
Estimate against measurement, compound 3: 2.0-fold (0.30 log units) below, within the range that was stated.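

In this assay, trifluoromethoxy in place of chloro on an aromatic carbon, para to a large group, gives a 1.5-fold higher number from compound 2 to compound 3 (0.19 log units; within the scatter). At this position, one heavy atom gives way to five, yet compound 2 and compound 3 cannot be told apart on this read-out. The only repeat shown agrees closely: the several entries of compound 1 in this assay, 2800 nM; 2820 nM (2 entries).

The compounds shown leave open how an amine or a carboxylic acid at this position would read out. They also leave open whether the same exchange would read alike on the core of compound 1.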